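The compounds below may be only part of what the source reports. "The series", "measured", "known", "first", "only" and "open" are said of these compounds alone.

Measured compounds:
compound 1 `CN(C)S(=O)(=O)Cc1noc2ccc(F)cc12`, 32 mg/kg
compound 2 `NS(=O)(=O)Cc1noc2ccc(Cl)cc12`, 14 mg/kg
compound 3 `CC(C)NS(=O)(=O)Cc1noc2ccc(Cl)cc12`, 100 mg/kg

In a functional assay on the whole organism (strain STD-dd) with Mus musculus as the target, in the maximal electroshock model, with a stated time of 2 h (on this read-out higher numbers stand for an effect only at larger amounts of compound and lower numbers for an effect already at smaller amounts), compound 3 stands highest of the three, with compound 1 nearest and compound 2 furthest away. The step to compound 4 `CN(C)S(=O)(=O)Cc1noc2ccc(Cl)cc12` is dimethylamino in place of isopropylamino on a sulfonyl sulfur. Among the measured compounds shown here, one measured step bears on this change: a 7.1-fold higher number from compound 2 to compound 3 (0.85 log units; beyond the scatter), which shows that adding a larger group on the sulfonamide nitrogen went with a clearly higher number. Compound 4 carries the same dimethylamino group as compound 1, and in this assay compound 1 gives 32 mg/kg. On that basis a lower number is expected from compound 3 to compound 4, a step of about a 3.3-fold lower number from compound 3 to compound 4 (0.52 log units; beyond the scatter). Compound 4 is therefore estimated at 30 mg/kg, with a likely range from 12 mg/kg to 80 mg/kg.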

Compound 4, dose for half-maximal effect: 57 mg/kg
Beside the measured number, compound 4's estimate is 1.9-fold (0.28 log units) below it; the measured number falls inside the stated range.
By their numbers in this assay, from the lowest: compound 2; then compounds 1, 4 and 3 (each within the scatter of the next, the first and the last beyond it).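

On a sulfonyl sulfur, dimethylamino in place of isopropylamino gives a 1.8-fold lower number from compound 3 to compound 4 (0.24 log units; within the scatter) and so does not separate these two groups, whereas dimethylamino in place of amino gives a 4.1-fold higher number from compound 2 to compound 4 (0.61 log units; beyond the scatter) and sets compound 2 clearly apart. With dimethylamino kept, chloro in place of fluoro on an aromatic carbon gives a 1.8-fold higher number from compound 1 to compound 4 (0.25 log units; within the scatter) and so does not separate this pair either. No measurement here explains these differences.

From the compounds shown here alone, whether methylamino or morpholino on the sulfonyl sulfur would match amino or dimethylamino remains open.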